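Benzyl in Place of an Aryl Group on the Amine Nitrogen

This account rests on a few compounds, and the source may have more. Where it says the series, first, only, none or still open, it means among the compounds named here.

Measured compounds:
compound 1, `O=C1C=C(Nc2ccc(I)cc2)C(=O)c2c1nc1n2[C@H]2OC[C@@H](O)[C@H]2OC1`: 2300 nM
compound 2, `Cc1ccc(NC2=CC(=O)c3nc4n(c3C2=O)[C@H]2OC[C@@H](O)[C@H]2OC4)cc1C`: 2820 nM

In a functional assay on ECa-109 cells for inhibition, with ECa-109 cell line (Homo sapiens) as the target, read by sulforhodamine B assay (a higher number here means a weaker inhibitor, a lower number a stronger inhibitor), compound 1 gives 2300 nM and compound 2 gives 2820 nM. Compound 2 stands at the higher of the two numbers, but the step of a 1.2-fold higher number from compound 1 to compound 2 (0.09 log units; within the scatter) lies within the scatter, so the two compounds cannot be told apart on these data. Compound 3, `O=C1C=C(NCc2ccccc2)C(=O)c2c1nc1n2[C@H]2OC[C@@H](O)[C@H]2OC1`, differs from compound 2 by benzyl in place of 3,4-dimethylphenyl on an amine nitrogen. Going by the values given here, the only measured step exchanged one substituted phenyl for another on the amine nitrogen and barely moved the number. Among the compounds with values here, no measured step exchanges an aromatic group for a benzyl group, so that change has no anchor here, and the uncertainty is correspondingly wide. The estimated step of a 1.2-fold higher number from compound 2 to compound 3 (0.09 log units; within the scatter) is expected to be modest, with a slight lean toward a higher number. For compound 3 the expected value is 3500 nM, with a range from 1200 nM to 10000 nM.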

Compound 3, half-maximal inhibitory concentration: > 8000 nM
Compound 3 ended at the assay's limit (the forecaster's own chance of this, stated with the estimate: 5%); middle value at least 2.2-fold (0.35 log units) from the limit.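

In this assay compound 3 gives a limit and not a number: the limit of > 8000 nM in this assay, at which 1 of the 3 values shown sits. The exchange between the two substituted phenyl groups stayed within the scatter, but benzyl on the amine nitrogen moves the number beyond it, with an at least 2.8-fold higher number from compound 2 to compound 3 (0.45 log units; beyond the scatter) and an at least 3.4-fold higher number from compound 1 to compound 3 (0.54 log units; beyond the scatter). Among the three compounds shown, this position therefore accepts either aryl group directly on the amine nitrogen with no readable difference, while the benzyl compound is the weaker inhibitor against both.

From the compounds shown here alone, how far compound 3 lies past its limit stays open, so both steps give only a minimum size. Also open, going by these compounds, is how an unsubstituted phenyl, a longer 2-phenylethyl chain or a benzyl group bearing a methyl or iodo substituent would read on the same amine nitrogen.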